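A Bulkier Chain on a Flat Set of Values

The compounds below may be only part of what the source reports. "The series", "measured", "known", "first", "only" and "open" are said of these compounds alone.

In a functional assay on A549 cells (Homo sapiens) for inhibition, read by MTT assay, with a stated time of 72 h (a lower number here means a stronger inhibitor, a higher number a weaker inhibitor), compound 1 `C=C(Cl)C(=O)Nc1cc(Nc2nc3c(c(-c4cn(C)c5ccc(F)cc45)n2)CS(=O)(=O)CC3)c(OC)cc1N(C)CCN(C)C` gives 3180 nM while compound 2 `COc1cc(N(C)CCN(C)C)c(NC(=O)C=C(C)C)cc1Nc1nc2c(c(-c3cn(C)c4ccc(F)cc34)n1)CS(=O)(=O)CC2` gives 2140 nM and compound 3 `C/C=C\C(=O)Nc1cc(Nc2nc3c(c(-c4cn(C)c5ccc(F)cc45)n2)CS(=O)(=O)CC3)c(OC)cc1N(C)CCN(C)C` gives 3990 nM in the same test. Compound 3 cannot be told apart from the other two: the steps of a 1.3-fold higher number from compound 1 to compound 3 (0.10 log units; within the scatter) and a 1.9-fold higher number from compound 2 to compound 3 (0.27 log units; within the scatter) both stay within the scatter. Compound 4 `COc1cc(N(C)CCN(C)C)c(NC(=O)/C=C\C(C)C)cc1Nc1nc2c(c(-c3cn(C)c4ccc(F)cc34)n1)CS(=O)(=O)CC2` differs from compound 3 by isopropyl in place of methyl on a double-bonded chain carbon bound to a double-bonded chain carbon with isopropyl in place of methyl on a double-bonded chain carbon bound to a double-bonded chain carbon. The remaining swap on the carbonyl carbon gave a 1.5-fold lower number from compound 1 to compound 2 (0.17 log units; within the scatter) and also stayed within the scatter, so no step beyond the scatter is expected in this assay here. The expected step of a 1.3-fold lower number from compound 3 to compound 4 (0.12 log units; within the scatter) is therefore small. For compound 4 the estimated value is 3000 nM with an expected range from 1400 nM to 6500 nM across repeat measurements.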

Compound 4, half-maximal inhibitory concentration: 3750 nM
For compound 4 the middle estimate is 1.3-fold (0.10 log units) below the measured one; low and high end bracket the measured number.
By their numbers in this assay, from the lowest: compounds 2, 1, 4 and 3 (each within the scatter of the next).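

Putting isopropyl in place of methyl on a double-bonded chain carbon bound to a double-bonded chain carbon gives a 1.1-fold lower number from compound 3 to compound 4 (0.03 log units; within the scatter) in this assay and so shows that this position accepts the branched group with no readable change. Compared with the other two carbonyl substituents, 3-methylbut-1-en-1-yl also stays within the scatter, with a 1.8-fold higher number from compound 2 to compound 4 (0.24 log units; within the scatter) and a 1.2-fold higher number from compound 1 to compound 4 (0.07 log units; within the scatter) in the same test. Nothing available here explains why these values stay so close. Going by these compounds, whether an amine or a carboxylic acid in place of isopropyl would give a step beyond the scatter remains open.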